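The source may hold more compounds than are shown below. What is called first, only, known or untested is meant among the compounds shown, and "the series" means these compounds.

Working notes on the series. Compound 1 `COc1ccc(-c2nc3cc(C(F)(F)F)ccc3[nH]2)cc1` gives 15000 nM in an ADME assay on Vero cells (Chlorocebus sabaeus) for cytotoxicity; on this read-out higher numbers stand for lower toxicity in this test and lower numbers for higher toxicity in this test. Compound 2 `CC(=O)Nc1ccc(-c2nc3cc(C(F)(F)F)ccc3[nH]2)cc1` gives 50000 nM in this assay, and compound 3 `Fc1ccc(-c2nc3cc(C(F)(F)F)ccc3[nH]2)cc1` gives 60000 nM. Compound 3 holds the highest of the three numbers, but its gap to compound 2 is within the scatter. The steps of a 3.3-fold higher number from compound 1 to compound 2 (0.52 log units; beyond the scatter) and a 4.0-fold higher number from compound 1 to compound 3 (0.60 log units; beyond the scatter) were modest, whereas a 1.2-fold higher number from compound 2 to compound 3 (0.08 log units; within the scatter) stayed within the scatter.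

Compound 4 `O=C(CN1CCCC1)Nc1ccc(-c2nc3cc(C(F)(F)F)ccc3[nH]2)cc1` differs from compound 3 in one place: (((pyrrolidin-1-yl)methyl)carbonyl)amino in place of fluoro on an aromatic carbon. Of the measured steps, a 1.2-fold higher number from compound 2 to compound 3 (0.08 log units; within the scatter) bears most directly on this change, acetamido and the entering group both being an amino carrying a carbonyl; no step beyond the scatter is therefore expected in this assay. Compound 4 is expected to give 50000 nM (range 20000 nM to 120000 nM). The expected step is a 1.2-fold lower number from compound 3 to compound 4 (0.08 log units; within the scatter).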

Compound 4, half-maximal cytotoxic concentration: > 100000 nM
Compound 4: a limit, no number (the forecaster's own chance of this, stated with the estimate: 25%); middle value at least 2.0-fold (0.30 log units) from the limit.
By their numbers in this assay, from the lowest: compound 1; then compounds 2 and 3 (each within the scatter of the next). At a limit, above all of these: compound 4.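

At this position, on an aromatic carbon para to a large group, compound 4 gives a limit and not a number: the limit of > 100000 nM in this assay, at which 1 of the 4 values shown sits. Read as floors, an at least 1.6-fold higher number from compound 3 to compound 4 (0.22 log units; that floor lies within the scatter) and an at least 2.0-fold higher number from compound 2 to compound 4 (0.30 log units; that floor lies within the scatter) do not separate the entering group from fluoro or acetamido, yet the five-membered ring on the chain brings no fall in the number. Only an at least 6.6-fold higher number from compound 1 to compound 4 (0.82 log units; beyond the scatter) clears the scatter. On these data alone, how far compound 4 lies past its limit stays open, as does how an open-chain diethylamino or a carboxylic acid on the same chain carbon would read.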